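Series notes: methyl for hydrogen in the phenyl ring

A few compounds are considered here, and "the series" means these few. Any claim that something is new, unique, unknown or untested is made for them only; others in the source may bear on it.

Among the compounds with values here, compound 1 `O=C(c1ccccc1)c1ccc(NS(=O)(=O)c2ccc(Cl)cc2Cl)cc1` is the only member of this set with a number: in an assay on CHO cells for binding affinity to integrin alpha-1 (Homo sapiens), read by WST assay, with a stated time of 2 h (on this read-out higher numbers stand for an effect only at larger amounts of compound and lower numbers for an effect already at smaller amounts), compound 1 gives 20000 nM. Compound 2 `O=C(c1ccccc1)c1ccc(NS(=O)(=O)c2ccccc2)cc1` carries no such number; in this assay compound 2 is reported as "not active" (no number reported), so it stands without a value that could be set against compound 1. Compound 3 `Cc1ccc(S(=O)(=O)Nc2ccc(C(=O)c3ccccc3)cc2)cc1`, not yet measured, differs from compound 2 by methyl in place of hydrogen on an aromatic carbon, phenyl to 4-methylphenyl. Within the data shown here, no measured step is available for this change. Given that compound 2 shows "not active" (no number reported) and compound 1 reaches only 20000 nM, the step from compound 2 to compound 3 is expected to be small, either nothing beyond the scatter or a weak gain at best, and a result reported again without a number is considered likely. For compound 3 in this assay the expected value is 30000 nM, with a range from 10000 nM to 100000 nM.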

Compound 3, half-maximal effective concentration: "not active" (no number reported)
Nothing numeric was reported for compound 3, and the estimate cannot be compared.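

Compound 2 and compound 3 are both reported as not active, without a number, so no step can be read between them. On these data alone, whether methyl in place of hydrogen changes binding at all remains open. No supporting evidence bears on this result.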